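This account rests on a few compounds, and the source may have more. Where it says the series, first, only, none or still open, it means among the compounds named here.

Measured so far:
- compound 1, `CCn1c(CNc2ccccc2)nnc1SCC(=O)Nc1ccc(C(=O)OC)cc1`, in an assay on isolated protein for inhibition of long-chain fatty acid transport protein 1 (Mus musculus); a higher number here means a weaker inhibitor, a lower number a stronger inhibitor: "not determined" (no result reported)
- compound 2, `CCn1nnc(-c2ccc(NC(=O)CSc3nnc(CNc4ccccc4)n3CC)cc2)n1`, this assay: > 10000 nM
- compound 3, `CCc1ccc2oc(CSc3nnc(CNc4ccccc4)n3CC)nc2c1`, this assay: 1800 nM

Compound 1 carries no result in this assay. For compound 2 the entry > 10000 nM is a limit of the assay, not a number; it sits at the limit of > 10000 nM in this assay, at which 1 of the 3 values shown sits. Within the data shown here, compound 3 therefore holds the only single number in the set, with 1800 nM, and nothing else can be ranked against it.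

Compound 4, `CCn1c(CNc2ccccc2)nnc1SCc1nc2cc(Cl)ccc2o1`, differs from compound 3 in one place: chloro in place of ethyl on an aromatic carbon. Among the measured compounds shown here, no step between two measured compounds is available to calibrate such an exchange, so the size of the step can only be guessed from the single anchor. Because compound 3 gives 1800 nM and the change is confined to one substituent on the fused ring, the expected step from compound 3 to compound 4 is a 1.1-fold higher number from compound 3 to compound 4 (0.05 log units; within the scatter), which stays within the usual scatter. Compound 4 is accordingly expected to give 2000 nM, with a range from 700 nM to 6000 nM.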

Compound 4, half-maximal inhibitory concentration: 2300 nM
Compound 4: middle estimate off by 1.2-fold (0.06 log units), on the low side; low and high end bracket the measured number.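

Among these compounds, the exchange of ethyl for chloro gives a 1.3-fold higher number from compound 3 to compound 4 (0.11 log units; within the scatter) in this assay and is the first step that can be read. On the six-membered aromatic ring of the fused system, a single chlorine atom thus stands in for the two-carbon ethyl with no difference that can be told from the scatter, so these two substituents cannot be separated at this position. Nothing at hand offers a reason for this result.

One exchange at one position cannot show whether a different kind of group there, such as an amine or a carboxylic acid, would move the number beyond the scatter. Equally open, going by these compounds, is what a plain hydrogen or a longer chain such as propyl would give at this same place on the ring.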